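A few compounds are considered here, and "the series" means these few. Any claim that something is new, unique, unknown or untested is made for them only; others in the source may bear on it.

Measured in a functional assay on HeLa cells (Homo sapiens) for antiproliferative activity, read by sulforhodamine B assay; on this read-out higher numbers stand for weaker inhibition of growth and lower numbers for stronger inhibition of growth:
- Compound 1 `O[C@H]1CO[C@H](COCc2ccccc2)[C@@H](OCc2ccccc2)[C@@H]1OCc1ccccc1`: > 50000 nM (a limit)
- Compound 2 `OCC[C@@H]1O[C@H](COCc2ccccc2)[C@@H](OCc2ccccc2)[C@H](OCc2ccccc2)[C@H]1O`: 30200 nM
- Compound 3 `O[C@@H]1[C@@H](OCc2ccccc2)[C@H](OCc2ccccc2)[C@@H](COCc2ccccc2)O[C@H]1c1ccccc1`: > 50000 nM (a limit)

Compound 3 has no exact number, only the limit > 50000 nM. The same is true of most of this small set, as shown by the limit of > 50000 nM in this assay, at which 2 of the 3 values shown sit. Compound 4 `O[C@@H]1[C@@H](OCc2ccccc2)[C@H](OCc2ccccc2)[C@@H](COCc2ccccc2)O[C@H]1Cc1ccccc1` carries benzyl in place of phenyl on a saturated ring carbon.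

Three measured steps change the group on that carbon: an at least 1.6-fold lower number from compound 1 to compound 2 (0.21 log units; that floor lies within the scatter), a step that the two limits leave unreadable from compound 1 to compound 3 and an at least 1.6-fold higher number from compound 2 to compound 3 (0.21 log units; that floor lies within the scatter). None of them is readable as a change beyond the scatter. No step beyond the scatter is therefore expected in this assay, and the direction is open. The expected step is an at least 1.2-fold lower number from compound 3 to compound 4 (0.09 log units; that floor lies within the scatter). For compound 4 the estimated value is 40000 nM, with an expected range from 15000 nM to 90000 nM.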

Compound 4, concentration for 50% growth inhibition: 17400 nM
The estimate for compound 4 lay 2.3-fold (0.36 log units) above the measured number; the measured number falls inside the stated range.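

Among these compounds, on the saturated ring carbon next to the ring oxygen, benzyl in place of phenyl gives the first change here that can be read beyond the scatter in this assay: an at least 2.8-fold lower number from compound 3 to compound 4 (0.45 log units; beyond the scatter). Benzyl in place of hydrogen also reads clearly, with an at least 2.8-fold lower number from compound 1 to compound 4 (0.45 log units; beyond the scatter). Benzyl and the 2-hydroxyethyl group of compound 2 cannot be told apart, with a 1.7-fold lower number from compound 2 to compound 4 (0.24 log units; within the scatter).

On these data alone, whether an amine or a longer chain such as 2-phenylethyl on this carbon would lower the number further stays open. The true sizes of the steps from compound 1 and compound 3 also stay open, as each of these two compounds has only a limit: the limit of > 50000 nM in this assay, at which 2 of the 4 values shown sit.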